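This account rests on a few compounds, and the source may have more. Where it says the series, first, only, none or still open, it means among the compounds named here.

Measured in an ADME assay on HEK-293T cells (Homo sapiens) for inhibition, read by CCK-8 assay, with a stated time of 48 h, tested at 20 uM; on this read-out higher numbers stand for more inhibition of growth at the one concentration tested and lower numbers for less inhibition of growth:

- compound 1 `COc1ccc(S(=O)(=O)Oc2ccccc2/C=C(\C#N)C(=O)Nc2nnc(-c3cccs3)s2)cc1` gives 40%
- compound 2 `COc1ccc(S(=O)(=O)Oc2ccccc2/C=C(\C#N)C(=O)Nc2nnc(Cc3ccccc3)s2)cc1` gives 23%
- compound 3 `COc1ccc(S(=O)(=O)Oc2ccccc2/C=C(\C#N)C(=O)Nc2nnc(Cc3ccc(Cl)cc3)s2)cc1` gives 26%

Compound 3 sits close to compound 2, with the step of a number 3 percentage points higher from compound 2 to compound 3 (within the scatter); the two cannot be told apart. Both lie clearly under compound 1, as the step of a number 14 percentage points lower from compound 1 to compound 3 (beyond the scatter) shows, and so does the step of a number 17 percentage points lower from compound 1 to compound 2 (beyond the scatter). The next compound, compound 4 `COc1ccc(S(=O)(=O)Oc2ccccc2/C=C(\C#N)C(=O)Nc2nnc(Cc3ccc(C)cc3)s2)cc1`, keeps everything but one group and turns 4-chlorobenzyl into 4-methylbenzyl: methyl in place of chloro on an aromatic carbon, para to a large group (methyl in place of chloro on an aromatic carbon). The two larger steps both replace thiophen-2-yl, a different change, so they say little here. The step that bears most directly is the one at this same place, chloro in place of hydrogen, from compound 2 to compound 3 at 26%, and it stayed within the scatter. A similarly small result is therefore expected, with no shift beyond the scatter in either direction. The expected change is a number 1 percentage points lower from compound 3 to compound 4 (within the scatter). For compound 4 the estimated value is 25%, with an expected range from 15% to 36%.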

Compound 4, percent growth inhibition at one concentration: 28%
The estimate for compound 4 lay 3 percentage points below the measured number, within the range that was stated.
By their numbers in this assay, from the lowest: compounds 2, 3 and 4 (each within the scatter of the next); then compound 1.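

In this assay, methyl in place of chloro on this aromatic carbon gives no step beyond the scatter (a number 2 percentage points higher from compound 3 to compound 4 (within the scatter)), and methyl in place of hydrogen gives none either (a number 5 percentage points higher from compound 2 to compound 4 (within the scatter)). Together with the earlier chloro step, this means that hydrogen, chloro and methyl at this place cannot be told apart, while the gap to the thiophen-2-yl compound holds for a third benzyl group (a number 12 percentage points lower from compound 1 to compound 4 (beyond the scatter)). Nothing available explains these results.

From the compounds shown here alone, it remains open whether an amine or a carboxylic acid on this carbon would give a step beyond the scatter. The compounds also do not tell whether a phenyl group in place of thiophen-2-yl would stay near compound 1 or fall with the benzyl compounds.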